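Phenylethynyl in place of tert-butylphenyl at the pyridine carbon

A few compounds are considered here, and "the series" means these few. Any claim that something is new, unique, unknown or untested is made for them only; others in the source may bear on it.

Measured compounds, with their values in an assay on CHO cells for antagonist activity at transient receptor potential cation channel subfamily V member 1 (Homo sapiens), read by FLIPR; a lower number here means a stronger inhibitor, a higher number a weaker inhibitor:
compound 1, `CC(C(=O)NCc1ccc(C(F)(F)F)nc1-c1ccc(C(C)(C)C)cc1)c1ccc(NS(C)(=O)=O)c(F)c1`, 0.5 nM
compound 2, `CC(C(=O)NCc1ccc(C(F)(F)F)nc1-c1ccc(Cl)c(Cl)c1)c1ccc(NS(C)(=O)=O)c(F)c1`, 0.9 nM
compound 3, `CC(C(=O)NCc1ccc(C(F)(F)F)nc1-c1ccco1)c1ccc(NS(C)(=O)=O)c(F)c1`, 5.8 nM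

Compound 1 gives the lowest number of the three in this assay. Compound 2 sits close to it, the step of a 1.8-fold higher number from compound 1 to compound 2 (0.26 log units; within the scatter) staying within the scatter, so the two are not ordered against each other. Compound 3 stands clearly apart: the step of a 12-fold higher number from compound 1 to compound 3 (1.06 log units; beyond the scatter) is large, and a 6.4-fold higher number from compound 2 to compound 3 (0.81 log units; beyond the scatter) points the same way.

Compound 4, `CC(C(=O)NCc1ccc(C(F)(F)F)nc1C#Cc1ccccc1)c1ccc(NS(C)(=O)=O)c(F)c1`, is not yet measured. It differs from compound 1 as follows: 2-phenylethynyl in place of 4-(tert-butyl)phenyl on an aromatic carbon.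

The two measured steps from compound 1 show that swapping the 4-(tert-butyl)phenyl for another six-membered aromatic group costs little, while the smaller furan-2-yl costs much. Within the data shown here, the 2-phenylethynyl group keeps a six-membered aromatic ring but carries it on a triple bond, a case none of the measured steps covers directly. The expectation for compound 4 in this assay is therefore a modest weakening, a 4.0-fold higher number from compound 1 to compound 4 (0.60 log units; beyond the scatter), with a wide range. Compound 4 is estimated at 2 nM, between 0.5 nM and 8 nM.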

Compound 4, inhibition constant: 0.8 nM
Compound 4: the middle estimate sits 2.5-fold (0.40 log units) above what was measured; the range from low to high includes it.
By their numbers in this assay, from the lowest: compounds 1, 4 and 2 (each within the scatter of the next); then compound 3.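

In this assay, the 2-phenylethynyl group stands level with both groups it was compared against (a 1.6-fold higher number from compound 1 to compound 4 (0.20 log units; within the scatter) and a 1.1-fold lower number from compound 2 to compound 4 (0.05 log units; within the scatter)), so a six-membered aromatic ring carried on a triple bond at this carbon next to the ring nitrogen cannot be told apart from the 4-(tert-butyl)phenyl or the 3,4-dichlorophenyl. The step from the furan-2-yl is beyond the scatter (a 7.3-fold lower number from compound 3 to compound 4 (0.86 log units; beyond the scatter)), which leaves compounds 1, 2 and 4, all with a six-membered aromatic ring of carbon only, together and compound 3 apart. Nothing measured here offers a reason for this.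

The compounds shown leave open how the value would respond to an amine or a carboxylic acid on the phenyl ring of the 2-phenylethynyl group. They also leave open what a cyclohexyl ring on the triple bond, or a saturated two-carbon chain in its place, would do.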